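Bromo for acetyl on the shared core

The source may report more compounds than this note shows. Statements on the series, on what has been measured and on what is new or still open speak of the compounds shown alone.

Compound 1 `CC(=O)c1ccc2c(c1)C(n1ccccc1=O)=CC(C)(C)O2` is tested in a functional assay (trachea) with Rattus norvegicus as the target; a lower number here means a less potent compound, a higher number a more potent compound, by a factor of ten per unit of this negative logarithm; in that assay compound 1 gives 6.65. Compound 2 `CC1(C)C=C(n2ccccc2=O)c2cc(OC(=O)Nc3ccc(C(F)(F)F)cc3)ccc2O1` gives 4.54 in this assay, a number beyond the scatter below compound 1, so compound 1 stands highest of the two measured compounds. Within the data shown here, no pair of measured compounds differs in one place only, so no single step is known. Compound 3 `CC1(C)C=C(n2ccccc2=O)c2cc(Br)ccc2O1` differs from compound 1 by bromo in place of acetyl on an aromatic carbon. A moderate loss beyond the scatter is expected, as the step from compound 1 to compound 3 is estimated at a number 0.85 log units lower from compound 1 to compound 3 (beyond the scatter). Compound 3 is expected to give about 5.8, with a range from 5 to 6.6.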

Compound 3, logarithm of the reciprocal of the active concentration, log(1/C): 7.53
Compound 3: middle estimate off by 1.73 log units, on the low side; the whole stated range lies below it.
By their numbers in this assay, from the lowest: compound 2; then compound 1; then compound 3.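

Working from the aromatic carbon that is meta to one fused ring bond and para to the other, the acetyl group is not needed for activity on the shared core: bromo in its place gives a number 0.88 log units higher from compound 1 to compound 3 (beyond the scatter). A group with no hydrogen-bond acceptor is therefore tolerated here, at least in this single pair. No measurement at hand accounts for this step. Still open, from the compounds shown here alone, is how chloro, a nitrile or an amine on this same carbon would compare with bromo and acetyl.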